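Amino in place of hydroxy in compound 2

The compounds below may be only part of what the source reports. "The series", "measured", "known", "first", "only" and "open" are said of these compounds alone.

In a functional assay on HT-1080 cells (Homo sapiens) for antiproliferative activity, read by MTT assay, with a stated time of 72 h (a higher number here means a weaker inhibitor, a lower number a stronger inhibitor), compound 1 (`COc1ccc(-c2ss/c(=N/O)c2-c2cc(OC)c(OC)c(OC)c2)cc1`) gives 6660 nM and compound 2 (`COc1ccc(-c2ss/c(=N/O)c2-c2cc(OC)c(OC)c(OC)c2)cc1O`) gives 730 nM as the lower of the two numbers. Compound 3 (`COc1ccc(-c2ss/c(=N/O)c2-c2cc(OC)c(OC)c(OC)c2)cc1N`) differs from compound 2 by amino in place of hydroxy on an aromatic carbon with amino in place of hydroxy on an aromatic carbon, ortho to a methoxy group. Within the data shown here, the one measured step at this carbon is a 9.1-fold lower number from compound 1 to compound 2 (0.96 log units; beyond the scatter) on adding the hydroxy, but no measured step compares amino with hydroxy. Only a small move is expected in this assay and the estimated step is a 1.1-fold higher number from compound 2 to compound 3 (0.04 log units; within the scatter) with nothing beyond the scatter foreseen. Compound 3 is expected at 800 nM and between 250 nM and 2500 nM in four of five measurements.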

Compound 3, half-maximal inhibitory concentration: 9360 nM
Estimate against measurement, compound 3: 12-fold (1.07 log units) below; the measured number lies above the stated range.
By their numbers in this assay, from the lowest: compound 2; then compounds 1 and 3 (each within the scatter of the next).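

In this assay, the gain at this carbon turns out to belong to hydroxy and not to any group with the same donor and acceptor counts: amino in place of hydroxy gives a 13-fold higher number from compound 2 to compound 3 (1.11 log units; beyond the scatter). Amino in place of hydrogen gives a 1.4-fold higher number from compound 1 to compound 3 (0.15 log units; within the scatter), so the 3-amino-4-methoxyphenyl compound cannot be told apart from the compound without a substituent here. Nothing available explains why hydroxy and amino part so sharply. As far as these compounds go, it remains open whether a hydroxymethyl group or a fluorine at this carbon would keep any of the hydroxy gain, and whether a methylamino or acetamido group would match amino.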